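This account rests on a few compounds, and the source may have more. Where it says the series, first, only, none or still open, it means among the compounds named here.

Measured compounds in a functional assay on TK-10 cells (Homo sapiens) for cytotoxicity, read by sulforhodamine B assay, with a stated time of 48 h, tested at 10 uM; on this read-out lower numbers stand for a stronger effect and higher numbers for a weaker effect at the one concentration tested:

Compound 1, `COc1ccc(-c2cc(/C=C/C(=O)c3ccc(N)cc3)[nH]n2)cc1`: compound 1 gives 12%.
Compound 2, `COc1ccc(C(=O)/C=C/c2cc(-c3cc(OC)c(OC)c(OC)c3)n[nH]2)cc1OC`: compound 2 gives 100%.
Compound 3, `COc1ccc(-c2cc(/C=C/C(=O)c3ccc(N)cc3)[nH]n2)cc1OC`: compound 3 gives 56%.

Compound 1 and compound 3 share a core and differ in one place only: methoxy in place of hydrogen on an aromatic carbon. That single change made a number 44 percentage points higher from compound 1 to compound 3 (beyond the scatter), which on this read-out means a markedly weaker effect after the methoxy enters. Compound 2 stands highest of the three numbers, beyond the scatter from both compound 3 and compound 1; the difference between the core of compound 2 and the core of compound 1 is not broken down here.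

Compound 4, `COc1cc(C(=O)/C=C/c2cc(-c3cc(OC)c(OC)c(OC)c3)n[nH]2)cc(OC)c1OC`, has not yet been measured in this assay. It differs from compound 2 by methoxy in place of hydrogen on an aromatic carbon. The surroundings of the place are not word for word those of the first pair: in compound 4 the entering methoxy is ortho to a methoxy group, meta to a large group and also meta to a methoxy group, whereas in compound 3 it is ortho to a methoxy group and meta to a large group only. The two are therefore the same kind of change, not the same change.

The earlier step weakened the effect by a large margin, but compound 2 already gives 100%, leaving essentially no room in that direction. The step from compound 2 to compound 4 is expected to be about a number 1 percentage points lower from compound 2 to compound 4 (within the scatter), within the scatter, because compound 2 sits at 100%. Compound 4 is expected to give roughly 99% in this assay, estimated to fall between 85% and 112%.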

Compound 4, a percentage reported as activity, at one concentration (the size of the read-out at that concentration, not a potency): -98%
Estimate against measurement, compound 4: 197 percentage points above, and the stated range ends above it.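

In this assay, methoxy in place of hydrogen on an aromatic carbon gives a number 198 percentage points lower from compound 2 to compound 4 (beyond the scatter), and set beside the earlier step, the change does not carry over from one core to the other, either in size or in direction: the same change on two cores in this assay, a number 44 percentage points higher (beyond the scatter) from compound 1 to compound 3 and a number 198 percentage points lower (beyond the scatter) from compound 2 to compound 4, 242 percentage points apart, beyond the scatter of two such steps

For this series, a step read on the core of compound 1 therefore gives no safe estimate of the same kind of change on the core of compound 2. This does not show what sets the two steps apart, since the two cores differ in more than one place and the entering methoxy in compound 4 also has a further meta methoxy group that the earlier place lacks; one pair on each core cannot separate these factors, nor does it give a rule for any other core.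

On these data alone, it remains open whether a hydroxy group, a chlorine atom or an ethoxy group at the same place on the core of compound 2 would follow the step to compound 4 or stay with compound 2. Also open, as far as these compounds go, is how methoxy would behave on the core of compound 2 if that core carried the amine found on the core of compound 1.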